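This account rests on a few compounds, and the source may have more. Where it says the series, first, only, none or still open, it means among the compounds named here.

Compound 1 `C=CCCCCOc1ccccc1-c1cnc(OCCC=C)n1C`: 9000 nM
Compound 2 `Cn1c(-c2ccccc2O)cnc1S(=O)(=O)c1ccccc1`: > 100000 nM, a limit of the assay
Compound 3 `C=CCCCCOc1ccccc1-c1cnc(S(=O)(=O)c2ccccc2)n1C`: 38000 nM

In a functional assay on A549 cells (Homo sapiens) for inhibition, read by colorimetric assay and MTT assay, with a stated time of 72 h (a lower number here means a stronger inhibitor, a higher number a weaker inhibitor), compound 3 gives 38000 nM, the higher of the two exact numbers, with a 4.2-fold higher number from compound 1 to compound 3 (0.63 log units; beyond the scatter). Compound 4 `C=CCCOc1ccccc1-c1cnc(S(=O)(=O)c2ccccc2)n1C` differs from compound 3 by vinyl in place of but-3-en-1-yl on a saturated chain carbon, two bonds along the chain from an oxygen on an aromatic ring: hex-5-en-1-yl becomes but-3-en-1-yl on the oxygen on an aromatic ring. The closest evidence is an at least 2.6-fold lower number from compound 2 to compound 3 (0.42 log units; beyond the scatter), a step that rests on a limit and concerns the same oxygen. The other step changes a different place and bears only indirectly. Compound 4 keeps a shorter chain there, so a small move toward a higher number is expected, possibly within the scatter. The expected step is a 1.6-fold higher number from compound 3 to compound 4 (0.20 log units; within the scatter). For compound 4 the estimated value is 60000 nM, with an expected range of 25000 nM to 100000 nM.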

Compound 4, half-maximal inhibitory concentration: 73000 nM
Compound 4: middle estimate off by 1.2-fold (0.09 log units), on the low side, and the stated range covers the measured number.
By their numbers in this assay, from the lowest: compound 1; then compounds 3 and 4 (each within the scatter of the next). At a limit, above all of these: compound 2.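

In this assay, replacing hex-5-en-1-yl with but-3-en-1-yl on the oxygen gives a 1.9-fold higher number from compound 3 to compound 4 (0.28 log units; within the scatter), so these two chain lengths are not told apart. With but-3-en-1-yl in place of hydrogen on that oxygen, the step is an at least 1.3-fold lower number from compound 2 to compound 4 (0.13 log units; that floor lies within the scatter), so compound 4, unlike compound 3, is not separated from compound 2. That comparison rests on a limit for compound 2: the limit of > 100000 nM in this assay, at which 1 of the 4 values shown sits.

As far as these compounds go, it remains open how a chain longer than hex-5-en-1-yl would read in this assay. Also open, from the compounds shown here alone, is the effect of an amine or a carboxylic acid in place of the vinyl.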